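Swapping 3-hydroxyphenyl for 2-fluorophenyl in a tolerated set

The source may report more compounds than this note shows. Statements on the series, on what has been measured and on what is new or still open speak of the compounds shown alone.

- Compound 1 `COc1ccc(-c2cnc(NC(=O)c3ccccc3O)n2C)cc1` gives > 100000 nM
- Compound 2 `COc1ccc(-c2cnc(NC(=O)CCc3ccccc3)n2C)cc1` gives > 100000 nM
- Compound 3 `COc1ccc(-c2cnc(NC(=O)c3cccc(O)c3)n2C)cc1` gives > 100000 nM

Each of these entries is a limit of the assay and not a number. In a toxicity assay on THP-1 cells (Homo sapiens) for inhibition (a higher number here means that more compound is tolerated, a lower number that less compound is tolerated), compound 3 gives > 100000 nM as its limit, the same entry as the other two compounds. Compound 4 `COc1ccc(-c2cnc(NC(=O)c3ccccc3F)n2C)cc1` carries 2-fluorophenyl in place of 3-hydroxyphenyl on a carbonyl carbon. The measured steps that bear on this change also alter the group at that place: a step that the two limits leave unreadable from compound 1 to compound 3 and a step that the two limits leave unreadable from compound 1 to compound 2 and a step that the two limits leave unreadable from compound 2 to compound 3 are all the evidence there is. None has a readable size, and the common ground is the limit of > 100000 nM in this assay, at which 3 of the 3 values shown sit, in each case. Compound 4 is therefore expected to sit at the same limit, with no shift in either direction beyond the scatter. The expected step is a number no higher from compound 3 to compound 4 (the limit leaves the size open) in this assay on this reading. The estimate for compound 4 is 100000 nM with 40000 nM to 200000 nM as its expected range.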

Compound 4, half-maximal cytotoxic concentration: > 100000 nM
Compound 4: no number, only a limit; the forecaster's own chance of this, stated with the estimate: 85%; the middle value lies on the limit itself.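

In this assay compound 4 gives > 100000 nM as a limit and not a number, so the steps to it from compound 1, compound 2 and compound 3 cannot be read. These four compounds leave open at what concentration each would become toxic to the cells, and whether the group on the carbonyl carbon matters for that.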